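Furan regioisomers on the shared core: cytotoxicity notes

The source may hold more compounds than are shown below. What is called first, only, known or untested is meant among the compounds shown, and "the series" means these compounds.

Measured so far:
Compound 1 `Nc1nc(N)c2c(-c3cc4ccccc4o3)cn([C@@H]3O[C@H](CO)[C@@H](O)[C@H]3O)c2n1`: in a functional assay on CEM-DNR-bulk cells (Homo sapiens), read by MTT assay, with a stated time of 72 h (a lower number here means a stronger inhibitor, a higher number a weaker inhibitor), compound 1 gives > 20000 nM, which is a limit of the assay and not a number.
Compound 2 `Nc1nc(N)c2c(-c3ccoc3)cn([C@@H]3O[C@H](CO)[C@@H](O)[C@H]3O)c2n1`: in this assay compound 2 gives > 20000 nM, again a limit and not a number.

Both measured compounds sit at the same limit, so the step that the two limits leave unreadable from compound 1 to compound 2 cannot be read in size or direction. Compound 2 therefore stands only at a limit on the numbers shown; the one further value is also a limit, and the limit of > 20000 nM in this assay, at which 2 of the 2 values shown sit, summarises the whole picture.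

Compound 3 `Nc1nc(N)c2c(-c3ccco3)cn([C@@H]3O[C@H](CO)[C@@H](O)[C@H]3O)c2n1` is the next member: furan-2-yl in place of furan-3-yl on an aromatic carbon. Within the data shown here, the only measured step, from compound 1 to compound 2, concerns an exchange of the aryl group at this same place and is itself unreadable, so it gives no size to carry over. Nothing in the data points to a readable change in this assay from compound 2 to compound 3, and the expected outcome for compound 3 is another limit rather than a number.

The estimate for compound 3 in this assay is 30000 nM, with a range from 10000 nM to 100000 nM.

The step that the limit leaves unreadable from compound 2 to compound 3 is the expected consequence, no change beyond the scatter.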

Compound 3, half-maximal inhibitory concentration: > 20000 nM
Compound 3: no number, only a limit; the forecaster's own chance of this, stated with the estimate: 85%; the middle value is on the limit's open side.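

In this assay compound 3 gives > 20000 nM as a limit of the assay and not a number. The steps joining compound 3 to compound 1 and to compound 2 therefore cannot be read, and no new step emerges: the limit of > 20000 nM in this assay, at which 3 of the 3 values shown sit.

The compounds shown leave open how compound 1, compound 2 and compound 3 rank, and whether any aryl group at this place gives a readable value in this assay at all.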